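The source may report more compounds than this note shows. Statements on the series, on what has been measured and on what is new or still open speak of the compounds shown alone.

Measured so far in a functional assay on K562 cells (Homo sapiens) for cytotoxicity, read by MTT assay; on this read-out higher numbers stand for weaker inhibition and lower numbers for stronger inhibition:
- compound 1 `C=CC(=O)Oc1cc(/C=C/C(=O)c2ccc(OC)c3c2OC(C)(C)C=C3)ccc1OC` gives 300 nM
- compound 2 `COc1ccc(/C=C/C(=O)Oc2cc(/C=C/C(=O)c3ccc(OC)c4c3OC(C)(C)C=C4)ccc2OC)cc1` gives 380 nM

Among the measured compounds shown here, compound 2 stands level with compound 1, within the scatter, and the only measured step is a 1.3-fold higher number from compound 1 to compound 2 (0.10 log units; within the scatter). Compound 3 `COc1ccc(/C=C/C(=O)c2ccc(OC)c3c2OC(C)(C)C=C3)cc1OS(=O)(=O)c1ccc(C)cc1` follows from compound 2 by (4-methylphenyl)sulfonyl in place of (2-(4-methoxyphenyl)ethenyl)carbonyl on an oxygen on an aromatic ring. For the measured compounds named here, the measured step changed a group on that carbonyl carbon and stayed within the scatter, but no measured compound carries the sulfonyl, so the guide is weak. In this assay no shift beyond the scatter is expected, in either direction. The expected change is a 1.2-fold higher number from compound 2 to compound 3 (0.07 log units; within the scatter). For compound 3 the estimate is 450 nM, with an expected range from 150 nM to 1400 nM.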

Compound 3, half-maximal inhibitory concentration: 7850 nM
For compound 3 the middle estimate is 17-fold (1.24 log units) below the measured one, and the stated range ends below it.
By their numbers in this assay, from the lowest: compounds 1 and 2 (each within the scatter of the next); then compound 3.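

On the oxygen on an aromatic ring, the range of groups tolerated in this assay ends at the sulfonyl: (4-methylphenyl)sulfonyl gives a 21-fold higher number from compound 2 to compound 3 (1.32 log units; beyond the scatter) and a 26-fold higher number from compound 1 to compound 3 (1.42 log units; beyond the scatter). The level values of compound 1 and compound 2 therefore hold only for the two carbonyl-linked groups, not for every group at this oxygen. Nothing available accounts for this loss. From the compounds shown here alone, whether it follows from the sulfonyl itself or from its 4-methylphenyl stays open, and a methanesulfonyl group would separate the two. Where a free hydroxyl on this oxygen would fall is also open.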